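Swapping a Propyl Chain for a 3-Fluorophenyl Ring

The source may hold more compounds than are shown below. What is called first, only, known or untested is meant among the compounds shown, and "the series" means these compounds.

In a functional assay on HUVEC cells (Homo sapiens) for inhibition, read by ELISA (on this read-out lower numbers stand for stronger inhibition and higher numbers for weaker inhibition), compound 2 `CCCc1nnc([S+]([O-])Cc2ncc(C)c(OC)c2C)o1` gives 8000 nM. Compound 1 `[O-][S+](Cc1ccccc1)c1nnc(-c2ccncc2)o1` gives 3000 nM, a number beyond the scatter below that of compound 2, while compound 3 `[O-][S+](Cc1ccccc1)c1nnc(-c2cccnc2)o1` gives 6000 nM, within the scatter of compound 2. Compound 4 `COc1c(C)cnc(C[S+]([O-])c2nnc(-c3cccc(F)c3)o2)c1C` differs from compound 2 in one place: 3-fluorophenyl in place of propyl on an aromatic carbon. For the measured compounds named here, the only measured step, a 2.0-fold higher number from compound 1 to compound 3 (0.30 log units; within the scatter), exchanges one pyridyl for another and does not bear on replacing a propyl chain with an aromatic ring. Compounds 1 and 3 carry an aromatic ring at this place, and compound 1 shows the clearly lower number, although their other arm also differs from compound 2. The expected step is therefore a modest fall in the number, a 2.0-fold lower number from compound 2 to compound 4 (0.30 log units; within the scatter). Compound 4 is estimated at 4000 nM, with a range from 1500 nM to 12000 nM.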

Compound 4, half-maximal inhibitory concentration: 12000 nM
For compound 4 the middle estimate is 3.0-fold (0.48 log units) below the measured one, within the range that was stated.
By their numbers in this assay, from the lowest: compounds 1, 3, 2 and 4 (each within the scatter of the next, the first and the last beyond it).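

Exchanging the propyl chain of compound 2 for a 3-fluorophenyl ring gives a 1.5-fold higher number from compound 2 to compound 4 (0.18 log units; within the scatter) in this assay and brings a six-membered aromatic ring to this place. This position on the shared core therefore accepts a larger group with a difference that stays within the usual scatter, which the pyridyl exchange between compound 1 and compound 3 could not show. No accompanying data explain this result.

As far as these compounds go, whether an amine, a carboxylic acid or a longer chain here would shift the number beyond the scatter remains open. From the compounds shown here alone, how a plain phenyl ring would compare with the 3-fluorophenyl ring also remains open.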